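From Ethyl to Phenoxy on a Shared Core

The source may report more compounds than this note shows. Statements on the series, on what has been measured and on what is new or still open speak of the compounds shown alone.

Measured so far in an ADME assay on J774 cells (Mus musculus) for cytotoxicity; on this read-out lower numbers stand for an effect already at smaller amounts and higher numbers for an effect only at larger amounts of compound:
Compound 1 (`CCOc1ccc2[nH]cc(C(=O)OC)c(=O)c2c1`) gives > 20000 nM, a limit.
Compound 2 (`CCc1ccc2[nH]cc(C(=O)OC)c(=O)c2c1`) gives > 20000 nM, a limit.

Compound 2 stands only at a limit, > 20000 nM, and the one other result is a limit too. The evidence so far comes down to the limit of > 20000 nM in this assay, at which 2 of the 2 values shown sit. For the measured compounds named here, the only measured step is a step that the two limits leave unreadable from compound 1 to compound 2, with ethyl in place of ethoxy, so it offers no size to carry forward. Compound 3 (`COC(=O)c1c[nH]c2ccc(Oc3ccccc3)cc2c1=O`) is not yet measured in this assay. It has phenoxy in place of ethyl on an aromatic carbon. On these data alone, with no readable step to lean on, no clear shift in either direction is expected, although this larger group remains untested. The expected change is a number no higher from compound 2 to compound 3 (the limit leaves the size open). For compound 3 the estimate is 20000 nM, with an expected range from 7000 nM to 40000 nM.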

Compound 3, half-maximal effective concentration: > 20000 nM
Compound 3 gave a limit, no number; the forecaster's own chance of this, stated with the estimate: 65%; the middle value sits exactly at the limit.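

In this assay compound 3 gives > 20000 nM, a limit and not a number. For the compounds shown here, with compound 1 and compound 2 also at limits, no step among the three can be read. The compounds shown leave open how far ethoxy, ethyl and phenoxy actually differ on this read-out.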